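The source may hold more compounds than are shown below. What is called first, only, known or untested is meant among the compounds shown, and "the series" means these compounds.

The series shares the core of compound 2 `Nc1ccc(CC2=NCCN2)cc1`. For the measured compounds named here, in a functional assay (thoracic aorta) with Rattus norvegicus as the target (on this read-out lower numbers stand for an effect already at smaller amounts and higher numbers for an effect only at larger amounts of compound), compound 2 gives 3000 nM, the lowest of the three numbers measured so far. Compound 1 `S=C=Nc1ccc(CC2=NCCN2)cc1I` gives 10000 nM in this assay, and compound 3 `O=C(CI)Nc1ccc(CC2=NCCN2)cc1` gives 47000 nM. Going by the values given here, the only measured step that alters the same place is a 16-fold higher number from compound 2 to compound 3 (1.19 log units; beyond the scatter), a large loss. Compound 4 `O=C(CCl)Nc1ccc(CC2=NCCN2)cc1` differs from compound 2 by (chloromethyl)carbonyl in place of hydrogen on a nitrogen on an aromatic ring. Because of a 16-fold higher number from compound 2 to compound 3 (1.19 log units; beyond the scatter) the change in compound 4 is expected to produce a large step in the same upward direction, a 10-fold higher number from compound 2 to compound 4 (1.00 log units; beyond the scatter), though perhaps somewhat smaller. Compound 4 is therefore estimated at 30000 nM in this assay, with a range from 8000 nM to 100000 nM.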

Compound 4, half-maximal effective concentration: 116000 nM
Compound 4: the middle estimate sits 3.9-fold (0.59 log units) below what was measured, and the stated range ends below it.
By their numbers in this assay, from the lowest: compound 2; then compound 1; then compound 3; then compound 4.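

In this assay the large loss on this aromatic nitrogen is not tied to the iodo group: (chloromethyl)carbonyl in place of hydrogen also gives a 39-fold higher number from compound 2 to compound 4 (1.59 log units; beyond the scatter), so both halogenated acyl groups lie well above the free amino compound. The halogen on the saturated chain carbon also counts, as chloro in place of iodo gives a 2.5-fold higher number from compound 3 to compound 4 (0.39 log units; beyond the scatter), a modest step. No evidence available here bears on the origin of either step. From the compounds shown here alone, it remains open whether the carbonyl alone carries the loss, which a plain acetyl group would test, and whether a bromo group on the same chain carbon would fall between the chloro and iodo compounds.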